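The source may report more compounds than this note shows. Statements on the series, on what has been measured and on what is new or still open speak of the compounds shown alone.

Measured compounds:

Compound 1, `COc1cccc(/C=C2\CCC/C(=C\c3cccc(Cl)c3)C2=O)c1OC`, gives 21400 nM in an ADME assay on NHDF cells (Homo sapiens) for cytotoxicity, read by MTT assay, with a stated time of 72 h; a lower number here means a stronger inhibitor, a higher number a weaker inhibitor.
Compound 2, `COc1cccc(/C=C2\CCC/C(=C\c3ccc(Cl)cc3)C2=O)c1OC`, gives 18600 nM in this assay.
Compound 3, `COc1ccc(/C=C2\CCC/C(=C\c3cccc(Cl)c3)C2=O)cc1OC`, gives 11900 nM in this assay.

All three numbers sit close together, and none of the gaps between them is larger than the scatter of repeated measurements, so the three compounds cannot be told apart on this read-out.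

Compound 4, `COc1ccc(/C=C2\CCC/C(=C\c3ccc(Cl)cc3)C2=O)cc1OC`, has not yet been measured. It differs from compound 3 by one change: 4-chlorophenyl in place of 3-chlorophenyl on a double-bonded chain carbon bound to a double-bonded ring carbon. The same kind of change has already been made once, from compound 1 to compound 2: 4-chlorophenyl in place of 3-chlorophenyl on a double-bonded chain carbon bound to a double-bonded ring carbon. That earlier step gave a 1.2-fold lower number from compound 1 to compound 2 (0.06 log units; within the scatter), a move too small to count as a real difference. The place at which the change is made is described in the same words for both pairs. The cores of compound 1 and compound 3 differ in a way that is not broken down here.

Among the measured compounds shown here, since the only measured example of this change, from compound 1 to compound 2, produced no step beyond the scatter, the expectation for compound 4 is that it will stay near compound 3, with an estimated step of a 1.1-fold lower number from compound 3 to compound 4 (0.05 log units; within the scatter). Compound 4 is therefore estimated at 10500 nM in this assay, most likely between 5000 nM and 22000 nM. This rests on a single earlier example, so the expectation is loose.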

Compound 4, half-maximal inhibitory concentration: 11200 nM
Compound 4: the middle estimate sits 1.1-fold (0.03 log units) below what was measured, within the range that was stated.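

On the second core, putting 4-chlorophenyl in place of 3-chlorophenyl gave a 1.1-fold lower number from compound 3 to compound 4 (0.03 log units; within the scatter) in this assay, a step too small to count as a real difference. Set beside the earlier step, the swap carried over from one core to the other in the plain sense that it moved the number by no real amount on either: the same change on two cores in this assay, a 1.2-fold lower number (0.06 log units; within the scatter) from compound 1 to compound 2 and a 1.1-fold lower number (0.03 log units; within the scatter) from compound 3 to compound 4, 1.1-fold (0.03 log units) apart, within the scatter of two such steps. This rests on just two pairs whose steps both lie within the scatter, so it does not show that a change with a real effect would carry across these cores in the same way, and it says nothing about cores other than these two or about any other read-out.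

All the compounds shown carry a chlorine on this phenyl ring, so it remains open whether an amine or a carboxylic acid in its place would move the number in this cell assay by more than the scatter. On these data alone, it also remains open whether such a group would give the same step on the core of compound 1 as on the core of compound 3.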